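Carbamoyl exchange on the aromatic carbon of compound 2

This account rests on a few compounds, and the source may have more. Where it says the series, first, only, none or still open, it means among the compounds named here.

In a functional assay on KB cells (Homo sapiens) for cytotoxicity, read by spectrophotometry and crystal violet staining (a lower number here means a stronger inhibitor, a higher number a weaker inhibitor), compound 1 `COC(=O)N/N=C/c1c(Cl)n(C2O[C@H](CO)[C@@H](O)[C@H]2O)c2cc(Cl)c(Cl)cc12` gives 20000 nM and compound 2 `NC(=O)c1c(Cl)n(C2O[C@H](CO)[C@@H](O)[C@H]2O)c2cc(Cl)c(Cl)cc12` gives 45000 nM as the higher of the two numbers, which makes compound 2 the weaker inhibitor of this pair. Among the compounds with values here, the only measured step is a 2.3-fold higher number from compound 1 to compound 2 (0.35 log units; beyond the scatter) and it falls on the same aromatic carbon that changes next. Compound 3 `OC[C@H]1OC(n2c(Cl)c(/C=N/O)c3cc(Cl)c(Cl)cc32)[C@H](O)[C@@H]1O` has the same atoms as compound 2, joined differently, and the difference is a group of 3 heavy atoms (1 carbon, 1 nitrogen, 1 oxygen; no ring) in place of a group of 3 heavy atoms (1 carbon, 1 nitrogen, 1 oxygen; no ring), on an aromatic carbon on an aromatic carbon next to the ring atom that bears a chloro group. No measurement covers this exact exchange, so the evidence is indirect. Within the data shown here, the one measured step at this carbon stayed modest, and it involved a larger group leaving than the exchange here. A large shift is therefore not expected. The expected change is a 1.8-fold lower number from compound 2 to compound 3 (0.26 log units; within the scatter) in this assay and points slightly towards a lower number, with no clear move beyond the scatter. Compound 3 is estimated at 25000 nM with an expected range from 7000 nM to 80000 nM as its spread.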

Compound 3, half-maximal inhibitory concentration: 25000 nM
Compound 3: middle estimate and measured number agree at the digits printed; the measured number falls inside the stated range.
By their numbers in this assay, from the lowest: compounds 1, 3 and 2 (each within the scatter of the next, the first and the last beyond it).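

Replacing carbamoyl with the group that carries hydroxy on a double-bonded nitrogen, using the same atoms joined differently, gives a 1.8-fold lower number from compound 2 to compound 3 (0.26 log units; within the scatter) in this assay, so this rearrangement at the aromatic carbon produces no readable difference. Hydroxy in place of (methoxycarbonyl)amino on the double-bonded nitrogen gives a 1.3-fold higher number from compound 1 to compound 3 (0.10 log units; within the scatter), which places compound 3 within the scatter of both of the other compounds, while the only separation in the series remains a 2.3-fold higher number from compound 1 to compound 2 (0.35 log units; beyond the scatter) and compound 3 cannot be assigned to either end of it. Nothing available explains why these numbers fall where they do.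

Going by these compounds, it remains open whether a carboxylic acid, an amine or a longer chain on this aromatic carbon would give a step clearly beyond the scatter, or whether the numbers would stay as close together as they do for these three groups. On these data alone, it is also open whether a group other than hydroxy or (methoxycarbonyl)amino on the double-bonded nitrogen, such as methoxy, would separate from compound 3 in this assay or stay within the scatter.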